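The source may hold more compounds than are shown below. What is called first, only, known or untested is meant among the compounds shown, and "the series" means these compounds.

In a physicochemical assay for acid dissociation, two compounds have been measured so far. Compound 1 `Cc1ccccc1-c1nc2cn(-c3cccc(C#N)c3)nc2c(=O)n1CC1CCCN(C(C)C)C1` gives 9.9 and compound 2 `COc1cccc(-n2cc3nc(-c4ccccc4C)n(CC4CCCN(C(C)C)C4)c(=O)c3n2)c1` gives 10. Going by the values given here, these two numbers lie within the scatter of each other, so compound 2 does not stand apart from the only other measured compound.

Compound 3 `Cc1ccccc1-c1nc2cn(-c3ccc(Cl)cc3)nc2c(=O)n1CC1CCCN(C(C)C)C1` keeps the shared core and differs from compound 2 in one group: 4-chlorophenyl in place of 3-methoxyphenyl on an aromatic nitrogen. Put plainly, 4-chlorophenyl comes in place of 3-methoxyphenyl on an aromatic nitrogen.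

Among the compounds with values here, only one measured step bears on this change, a number 0.10 log units higher from compound 1 to compound 2 (within the scatter). That step exchanged a group on the aromatic ring that is now replaced as a whole, and it stayed within the scatter. Within the data shown here, no measured compound carries a 4-chlorophenyl, so this single small step is thin evidence. On that evidence, no step beyond the scatter is expected in this assay. The estimated step is a number 0.10 log units lower from compound 2 to compound 3 (within the scatter). Compound 3 is expected to read 9.9, with an estimated range from 9.6 to 10.2.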

Compound 3, acid dissociation constant: 10
For compound 3 the middle estimate is 0.10 log units below the measured one; the range from low to high includes it.
By their numbers in this assay, from the lowest: compounds 1, 2 and 3 (each within the scatter of the next).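

Compound 3 takes the test further than the earlier pair, whose one step only exchanged cyano for methoxy on the aromatic group. Here the whole aromatic group on the aromatic nitrogen is exchanged, with chlorine as a new substituent and 4-chlorophenyl in place of a 3-substituted phenyl, and in this assay the step stays within the scatter (no change at the digits printed from compound 2 to compound 3 (within the scatter)), as does the comparison with the nitrile-bearing compound (a number 0.10 log units higher from compound 1 to compound 3 (within the scatter)). Across the three groups carried at this position, 3-cyanophenyl, 3-methoxyphenyl and 4-chlorophenyl, the read-out therefore does not separate the compounds, and none of the three goes against that; nothing available explains this result.

Going by these compounds, all three compounds share the rest of the structure and place a substituted phenyl on this nitrogen, so it remains open whether a group of another kind there, such as a phenyl ring bearing a carboxylic acid or an amine, or a plain alkyl chain in place of the phenyl, would give a step beyond the scatter. Changes elsewhere on the shared core also remain open, including replacement of the isopropyl group on the saturated ring.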